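Amide acyl variation and volume of distribution in the series

The compounds below may be only part of what the source reports. "The series", "measured", "known", "first", "only" and "open" are said of these compounds alone.

Compound 2 `CCC(=O)N1CC[C@H](Nc2ncnc3c2nc(-c2cnc(C)nc2)n3CC)C1` gives 3.6 L/kg in an ADME assay (Rattus norvegicus, strain Wistar Han) for pharmacokinetics (a higher number here means that more of the compound sits outside the plasma, a lower number that more of the compound stays in the plasma), the lowest of the two numbers in hand. The nearest is compound 1 `CCn1c(-c2cnc(C)nc2)nc2c(N[C@H]3CCN(C(=O)c4cocn4)C3)ncnc21`, which in this assay gives 6.1 L/kg; the step of a 1.7-fold lower number from compound 1 to compound 2 (0.23 log units; within the scatter) stays within the scatter, so the two cannot be ranked on these data.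

Compound 3 `CCn1c(-c2cnc(C)nc2)nc2c(N[C@H]3CCN(C(=O)C4CC4)C3)ncnc21` is not yet measured. It differs from compound 2 on the carbonyl carbon where compound 1 and compound 2 already differ: cyclopropyl in place of ethyl on a carbonyl carbon. For the measured compounds named here, the only measured step that bears on this carbonyl carbon is a 1.7-fold lower number from compound 1 to compound 2 (0.23 log units; within the scatter), where replacing a 1,3-oxazol-4-yl by an ethyl left the number within the scatter. Going by the values given here, no measured compound carries a cyclopropyl on this carbonyl carbon, so nothing in hand speaks to that group directly; by the one precedent, no step beyond the scatter is expected in this assay. The expected step is a 1.1-fold higher number from compound 2 to compound 3 (0.05 log units; within the scatter). For compound 3 the estimate is 4 L/kg, with a range from 2.2 L/kg to 7.5 L/kg.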

Compound 3, volume of distribution: 6.3 L/kg
Compound 3: middle estimate off by 1.6-fold (0.20 log units), on the low side; the range from low to high includes it.
By their numbers in this assay, from the lowest: compounds 2, 1 and 3 (each within the scatter of the next).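

In this assay the carbonyl carbon now carries three different groups, and the new one separates from neither of the others: cyclopropyl in place of ethyl (a 1.8-fold higher number from compound 2 to compound 3 (0.24 log units; within the scatter)) and cyclopropyl in place of 1,3-oxazol-4-yl (a 1.0-fold higher number from compound 1 to compound 3 (0.01 log units; within the scatter)) both stay within the scatter. An open ethyl chain, a three-membered ring of carbon only and a 1,3-oxazol-4-yl therefore cannot be ranked at this place, so the added ring and the extra carbon of the cyclopropyl show no readable effect on the number here. No evidence in hand explains this flat reading.

From the compounds shown here alone, whether any group on this carbonyl carbon can move the number beyond the scatter stays open, and an amine, a carboxylic acid or a longer chain at this place would test that. Going by these compounds, all three compounds share one core, so it also stays open whether these groups would read the same way on a different core.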